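A few compounds are considered here, and "the series" means these few. Any claim that something is new, unique, unknown or untested is made for them only; others in the source may bear on it.

Of the compounds shown here, three have so far been measured in a physicochemical assay for solubility; a lower number here means a less soluble compound, a higher number a more soluble compound. Compound 1 `NC(=O)c1ccc(NC(=O)c2cc3ccccc3s2)cc1` gives 25 ug/mL, and compound 3 `COC(=O)c1cccc(NC(=O)c2ccc3ccccc3n2)c1` gives 25 ug/mL. Compound 2 `NCc1ccccc1NC(=O)c1cnc2ccccc2c1` gives 5 ug/mL, the lowest of the three numbers, and its gap to each of the other two lies beyond the scatter. Compound 4 `O=C(Nc1ccccc1)c1cnc2ccccc2c1` has not yet been measured in this assay. It differs from compound 2 in one place: hydrogen in place of aminomethyl on an aromatic carbon. For the measured compounds named here, no pair of measured compounds differs by a single change, so this change has no precedent in the data. The expected step of a 1.3-fold lower number from compound 2 to compound 4 (0.10 log units; within the scatter) is therefore small, within the scatter, with no definite direction. In this assay compound 4 is estimated at 4 ug/mL, within a range from 1.5 ug/mL to 12 ug/mL.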

Compound 4, solubility: 5 ug/mL
For compound 4 the middle estimate is 1.3-fold (0.10 log units) below the measured one, within the range that was stated.
By their numbers in this assay, from the lowest: compounds 2 and 4 (each within the scatter of the next); then compounds 1 and 3 (each within the scatter of the next).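

For the compounds shown here, the first comparison in this set that differs in one place shows that, in this assay, hydrogen in place of aminomethyl on this aromatic carbon, ortho to a large group, brings no change at the digits printed from compound 2 to compound 4 (within the scatter) for this pair. In this one pair, then, the read-out does not depend on the aminomethyl group being present. Nothing available bears on why this is so. Going by these compounds, whether a carboxylic acid, a dimethylamine or a longer chain on the same carbon would also leave the number in place stays open. So does whether the same change would read alike on the core of compound 1 or of compound 3.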